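The compounds below may be only part of what the source reports. "The series", "measured", "known", "first", "only" and "open" are said of these compounds alone.

Among the measured compounds shown here, in a functional assay on MCF7 cells (Homo sapiens) for antiproliferative activity, read by colorimetric assay and MTT assay, with a stated time of 48 h (on this read-out higher numbers stand for weaker inhibition and lower numbers for stronger inhibition), compound 3 (`O=C(NS(=O)(=O)c1ccc(F)cc1)c1ccncc1`) gives 13900 nM and has the highest number of the three compounds measured so far. Compound 2 (`Cc1ccc(S(=O)(=O)NC(=O)c2cncc(C(=O)NS(=O)(=O)c3ccc(C)cc3)c2)cc1`) gives 10800 nM and lies within the scatter of compound 3, so the two cannot be told apart. Compound 1 (`O=C(NS(=O)(=O)c1ccc(Cl)cc1)c1cncc(C(=O)NS(=O)(=O)c2ccc(Cl)cc2)c1`) gives 4200 nM and sits lower than compound 3 by more than the scatter.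

Compound 4 (`O=C(NS(=O)(=O)c1ccc(Cl)cc1)c1ccncc1`) keeps everything in compound 3 except one group: it carries chloro in place of fluoro on an aromatic carbon, para to a large group (chloro in place of fluoro on an aromatic carbon). For the measured compounds named here, no measured pair isolates this change, so the data give no direct guide to it. Going by the values given here, compound 1 is the only measured compound that bears chloro, and its value of 4200 nM is a weak hint at best, since it differs from compound 3 in far more than that group. In this assay a small shift toward a lower number is therefore expected, with no clear separation from compound 3. The expected change is a 1.4-fold lower number from compound 3 to compound 4 (0.14 log units; within the scatter) and is estimated to stay within the scatter. For compound 4 the expected value is 10000 nM (estimated range 5000 nM to 20000 nM).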

Compound 4, half-maximal inhibitory concentration: 10100 nM
Compound 4: the middle estimate sits 1.0-fold (0.00 log units) below what was measured; measured number inside the range.
By their numbers in this assay, from the lowest: compound 1; then compounds 4, 2 and 3 (each within the scatter of the next).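

Among the compounds shown here, this pair gives the first direct reading of a change at this place, on an aromatic carbon para to a large group: in this assay chloro in place of fluoro gives a 1.4-fold lower number from compound 3 to compound 4 (0.14 log units; within the scatter) and so leaves the two compounds indistinguishable. On this core, then, swapping one of these halogens for the other does not separate the values, something compound 1 could not show, as it differs from compound 3 in more than one place. Nothing available accounts for this result or offers a measured property that bears on it.

Open, as far as these compounds go, is whether any other kind of group at this same place, such as a methoxy, a trifluoromethyl, an amine or a carboxylic acid, would move the number beyond the scatter, as one halogen in place of the other does not. Also open is what sets compound 1 apart from the others, as no pair among the compounds shown differs from it in one place and so isolates the feature behind its value.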